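A few compounds are considered here, and "the series" means these few. Any claim that something is new, unique, unknown or untested is made for them only; others in the source may bear on it.

Measured in an ADME assay on microsomes from liver (Homo sapiens) for metabolic stability, read by LC-MS, using NADPH, tested at 5 uM; on this read-out higher numbers stand for a longer-lived compound and lower numbers for a shorter-lived compound:
- compound 1 `Cc1cc(S(=O)(=O)/N=C(\N)n2nccc2-c2ccccc2)c(SCc2cccc(Cl)c2)cc1Cl`: 0.309 h
- compound 2 `Cc1cc(-c2ccccc2)n(/C(N)=N/S(=O)(=O)c2cc(C)c(Cl)cc2SCc2ccc(C(F)(F)F)cc2)n1`: 0.241 h
- compound 3 `Cc1cc(S(=O)(=O)/N=C(\N)n2nccc2-c2ccccc2)c(SCc2ccc(C(F)(F)F)cc2)cc1Cl`: 0.176 h

Compound 2 stands between the other two on half-life: compound 1 gives 0.309 h and compound 3 gives 0.176 h, and both gaps to compound 2 lie within the scatter, so no ordering among the three is secure.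

Compound 4 `Cc1cc(-c2ccccc2)n(/C(N)=N/S(=O)(=O)c2cc(C)c(Cl)cc2SCc2cccc(Cl)c2)n1` has not been measured. It differs from compound 2 in one place: 3-chlorophenyl in place of 4-(trifluoromethyl)phenyl on a saturated chain carbon bound to a sulfur. The same exchange, run the other way, is already seen between compound 1 and compound 3: a 1.8-fold lower number from compound 1 to compound 3 (0.24 log units; within the scatter), a step that stays within the scatter. The other measured step, a 1.4-fold lower number from compound 2 to compound 3 (0.14 log units; within the scatter), concerns a different change and does not bear on this pair.

Reversing the compound 1 to compound 3 exchange therefore suggests, for compound 4, a number somewhat higher than that of compound 2, but the expected shift is no larger than the scatter and could as well be nil. The step from compound 2 to compound 4 is estimated at a 1.7-fold higher number from compound 2 to compound 4 (0.22 log units; within the scatter). Compound 4 is expected to give 0.4 h, within a range of 0.22 h to 0.75 h.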

Compound 4, half-life: 0.205 h
Estimate against measurement, compound 4: 2.0-fold (0.29 log units) above, and the stated range ends above it.
By their numbers in this assay, from the lowest: compounds 3, 4, 2 and 1 (each within the scatter of the next).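

In this assay, 3-chlorophenyl in place of 4-(trifluoromethyl)phenyl on a saturated chain carbon bound to a sulfur now has a reading on a second core, a 1.2-fold lower number from compound 2 to compound 4 (0.07 log units; within the scatter), and the two readings of this change do not separate: the same change on two cores in this assay, a 1.8-fold lower number (0.24 log units; within the scatter) from compound 1 to compound 3 and a 1.2-fold higher number (0.07 log units; within the scatter) from compound 4 to compound 2, 2.1-fold (0.31 log units) apart, within the scatter of two such steps. Methyl in place of hydrogen on an aromatic carbon can also now be read on a second pair, a 1.5-fold lower number from compound 1 to compound 4 (0.18 log units; within the scatter), and these two readings likewise stay together: the same change on two cores in this assay, a 1.4-fold lower number (0.14 log units; within the scatter) from compound 2 to compound 3 and a 1.5-fold higher number (0.18 log units; within the scatter) from compound 4 to compound 1, 2.1-fold (0.31 log units) apart, within the scatter of two such steps. Across the four compounds, neither change gives a step beyond the scatter, so half-life at this position does not distinguish the two aryl groups, with or without the methyl.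

The compounds shown hold only these two substituted phenyl groups at this position, so it remains open whether an amine or a carboxylic acid on the phenyl, or a longer chain between the sulfur and the phenyl, would move half-life beyond the scatter. Going by these compounds, with every step here within the scatter, it also remains open whether the two changes act independently of each other.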